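The source may hold more compounds than are shown below. What is called first, only, known or untested is meant among the compounds shown, and "the series" means these compounds.

Measured so far:
- compound 1, `CSc1ccc(-c2nc3c(=O)n(C)c(=O)n(C)c3[nH]2)cc1`: 2 nM
- compound 2, `CCCn1c(=O)c2nc(-c3ccccc3N)[nH]c2n(CCC)c1=O`: 0.75 nM

In an assay for binding affinity to adenosine receptor A1 (Bos taurus) (a higher number here means a weaker inhibitor, a lower number a stronger inhibitor), compound 1 gives 2 nM and has the higher of the two numbers; its nearest neighbour is compound 2, which in this assay gives 0.75 nM, a gap that lies beyond the scatter. The two differ at several places, so nothing is learned from that pair about a single change.

The step under study is from compound 1 to compound 3, `Cn1c(=O)c2nc(-c3ccc(Br)cc3)[nH]c2n(C)c1=O`. The change is bromo in place of methylsulfanyl on an aromatic carbon, on the ring that is attached to the shared core, para to a large group. Among the compounds with values here, no measured pair shows this exchange, so the expected size of the step rests on compound 1 alone: a small move, toward a higher number if any, is expected, and it may well stay within the scatter. Compound 3 is accordingly estimated at 4 nM in this assay, in a range of 1 nM to 15 nM, which corresponds to an expected step of a 2.0-fold higher number from compound 1 to compound 3 (0.30 log units; within the scatter).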

Compound 3, half-maximal inhibitory concentration: 0.75 nM
Beside the measured number, compound 3's estimate is 5.3-fold (0.73 log units) above it, outside the stated range (below it).
By their numbers in this assay, from the lowest: compounds 2 and 3 (each within the scatter of the next); then compound 1.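

In this assay this place on the aromatic ring, para to a large group, now has its first comparison across a single change: a 2.7-fold lower number from compound 1 to compound 3 (0.43 log units; beyond the scatter). The step is modest but beyond the scatter, so the number at this place does respond to bromo in place of methylsulfanyl, and the loss of the sulfur and its carbon does not cost binding here. No measurement shown bears on why the number moves.

With a single exchange shown, it remains open whether other groups at this place, such as an amine, a carboxylic acid or a longer chain like butyl, would move the number in the same direction. On these data alone, it is also open whether the bromo step would carry over to a core with other substituents.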